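Taking the chloro group off compound 2

The source may report more compounds than this note shows. Statements on the series, on what has been measured and on what is new or still open speak of the compounds shown alone.

In a functional assay on HCT-116 cells (Homo sapiens) for inhibition, read by sulforhodamine B assay, with a stated time of 48 h, tested at 10 uM (a lower number here means less inhibition of growth, a higher number more inhibition of growth at the concentration tested), compound 2 (`Clc1ccc(-c2cn3nc(-c4ccccc4)nc3s2)cc1`) gives 41% and stands second of three numbers. Compound 1 (`COc1ccc(-c2nc3sc(-c4ccccc4)cn3n2)cc1`) gives 60% and sits higher, while compound 3 (`COc1ccc(-c2nc3sc(-c4ccc(Cl)cc4)cn3n2)cc1`) gives -16% and sits lowest. Compound 4 (`c1ccc(-c2nc3sc(-c4ccccc4)cn3n2)cc1`) has not been measured. It differs from compound 2 by hydrogen in place of chloro on an aromatic carbon and nothing else. The same swap run in reverse gave a number 76 percentage points lower from compound 1 to compound 3 (beyond the scatter) and so points to a rise, while adding methoxy gave a number 57 percentage points lower from compound 2 to compound 3 (beyond the scatter) as the other large step. A rise of the full size would pass complete inhibition, so the expected step is smaller, an estimated a number 29 percentage points higher from compound 2 to compound 4 (beyond the scatter) and no more. For compound 4 the expected value is 70% with an estimated range from 40% to 100% in this assay here.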

Compound 4, percent growth inhibition at one concentration: 11%
Compound 4: the middle estimate sits 59 percentage points above what was measured; measured number below the stated range.
By their numbers in this assay, from the lowest: compound 3; then compound 4; then compound 2; then compound 1.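

Hydrogen in place of chloro in this assay gives a number 30 percentage points lower from compound 2 to compound 4 (beyond the scatter), so chloro raises the number on this core, yet it lowers the number on the core that carries methoxy: the same change on two cores in this assay, a number 76 percentage points lower (beyond the scatter) from compound 1 to compound 3 and a number 30 percentage points higher (beyond the scatter) from compound 4 to compound 2, 106 percentage points apart, beyond the scatter of two such steps. Hydrogen in place of methoxy gives a number 49 percentage points lower from compound 1 to compound 4 (beyond the scatter), so methoxy also raises the number alone and lowers it when chloro is present: the same change on two cores in this assay, a number 57 percentage points lower (beyond the scatter) from compound 2 to compound 3 and a number 49 percentage points higher (beyond the scatter) from compound 4 to compound 1, 106 percentage points apart, beyond the scatter of two such steps. The effect of each group therefore depends on the other, and neither can be read alone.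

From the compounds shown here alone, it remains open whether an amine or a carboxylic acid in place of chloro would show the same reversal when methoxy is present.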